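A Difluorophenyl Sulfonamide Traced From an Inactive Pyridyl Analogue

The source may report more compounds than this note shows. Statements on the series, on what has been measured and on what is new or still open speak of the compounds shown alone.

Measured compounds:
compound 1 `CC1CCN(C2CCN(S(=O)(=O)c3cccnc3F)CC2)CC1` — > 5000 nM
compound 2 `Cc1cc(C)c(S(=O)(=O)N2CCC(N3CCC(Cc4ccccc4)CC3)CC2)c(C)c1` — 3.5 nM

In a functional assay on DLD-1 cells (Homo sapiens) for antiproliferative activity, read by CellTiter-Glo, with a stated time of 72 h (a lower number here means a stronger inhibitor, a higher number a weaker inhibitor), compound 1 gives > 5000 nM, which is a limit of the assay rather than a number, sitting at the limit of > 5000 nM in this assay, at which 1 of the 2 values shown sits. Compound 2 gives 3.5 nM in this assay. Compound 3 `CC1CCN(C2CCN(S(=O)(=O)c3ccc(F)cc3F)CC2)CC1` differs from compound 1 in one place: 2,4-difluorophenyl in place of 2-fluoropyridin-3-yl on a sulfonyl sulfur. Among the measured compounds shown here, no pair of measured compounds differing in a single place is available to gauge this change, so its size cannot be read from the data. A modest gain is expected, with the step estimated as an at least 1.6-fold lower number from compound 1 to compound 3 (0.22 log units; that floor lies within the scatter). Compound 3 is expected to reach 3000 nM, with a range of 500 nM to 10000 nM.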

Compound 3, half-maximal inhibitory concentration: 102 nM
Beside the measured number, compound 3's estimate is 29-fold (1.47 log units) above it, outside the stated range (below it).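

On a sulfonyl sulfur, 2,4-difluorophenyl in place of 2-fluoropyridin-3-yl gives an at least 49-fold lower number from compound 1 to compound 3 (1.69 log units; beyond the scatter) in this assay. The aryl group at this place therefore decides whether the shared core gives a measurable number at all, which compound 1 alone could not show. The size of this step is only a floor, because the value of compound 1 is a limit of the assay and not a number: the limit of > 5000 nM in this assay, at which 1 of the 3 values shown sits.

The compounds shown leave open what a plain phenyl group would give at this place. They therefore do not separate the loss of the ring nitrogen from the gain in fluorine.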